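Swapping methyl for chloro in compound 2

The compounds below may be only part of what the source reports. "The series", "measured", "known", "first", "only" and "open" are said of these compounds alone.

Compound 1 `COc1cc(-c2ncnn2-c2cccc(F)c2)cc(OC)c1OC`: > 10000 nM
Compound 2 `COc1cc(-n2ncnc2-c2ccc(C)cc2)cc(OC)c1OC`: > 10000 nM
Compound 3 `COc1cc(-c2ncnn2-c2cccc(N)c2)cc(OC)c1OC`: > 10000 nM

All three results come from a functional assay on K562 cells (Homo sapiens) for antiproliferative activity, read by MTT assay, with a stated time of 72 h; a higher number here means a weaker inhibitor, a lower number a stronger inhibitor. Compound 2 gives > 10000 nM, which is a limit and not a number. The whole set stands at the limit of > 10000 nM in this assay, at which 3 of the 3 values shown sit.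

The untested compound 4 `COc1cc(-n2ncnc2-c2ccc(Cl)cc2)cc(OC)c1OC` differs from compound 2 by one swap: chloro in place of methyl on an aromatic carbon. In words, 4-methylphenyl becomes 4-chlorophenyl. Going by the values given here, the only measured step, a step that the two limits leave unreadable from compound 1 to compound 3, is a different swap, amino in place of fluoro, and has no readable size. It therefore gives no guide, and no step beyond the scatter is expected in this assay, in either direction. The expected change is a step that the limit leaves unreadable from compound 2 to compound 4. For compound 4 the estimate is 12000 nM, with an expected range of 3000 nM to 40000 nM.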

Compound 4, half-maximal inhibitory concentration: > 10000 nM
Compound 4: a limit, no number (the forecaster's own chance of this, stated with the estimate: 80%); the middle value does not contradict the limit.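

No step from compound 2 to compound 4 can be read, because both results are limits and not numbers: the limit of > 10000 nM in this assay, at which 4 of the 4 values shown sit.

The compounds shown leave open whether 4-methylphenyl and 4-chlorophenyl differ at all in this assay.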